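Removing the chain methyl from compound 2: liver microsome stability

The source may hold more compounds than are shown below. What is called first, only, known or untested is meant among the compounds shown, and "the series" means these compounds.

Measured so far:
compound 1 `NS(=O)(=O)CC(=O)NCCSc1nonc1/C(=N/O)Nc1cccc(Cl)c1`: 1.26 h
compound 2 `C[C@H](CSc1nonc1/C(=N/O)Nc1ccc(F)c(Br)c1)NC(=O)CS(N)(=O)=O`: 0.537 h

In an ADME assay on microsomes from liver (Mus musculus) for metabolic stability (on this read-out lower numbers stand for a shorter-lived compound and higher numbers for a longer-lived compound), compound 2 gives the lowest of the two numbers; compound 1 gives a higher half-life, and that gap lies beyond the scatter. Compound 3 `NS(=O)(=O)CC(=O)NCCSc1nonc1/C(=N/O)Nc1ccc(F)c(Br)c1` differs from compound 2 by hydrogen in place of methyl on a saturated chain carbon bound to an amide-type nitrogen and a saturated chain carbon. For the measured compounds named here, compound 3 also shares the unmethylated chain of compound 1, though it carries a different aryl group, so no single-change step is available. The step from compound 2 to compound 3 is expected to be modest, a 1.4-fold higher number from compound 2 to compound 3 (0.15 log units; within the scatter), leaning upward but possibly within the scatter. Compound 3 is estimated at 0.75 h, within 0.35 h to 1.6 h.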

Compound 3, half-life: 1.12 h
For compound 3 the middle estimate is 1.5-fold (0.17 log units) below the measured one; the range from low to high includes it.
By their numbers in this assay, from the lowest: compound 2; then compounds 3 and 1 (each within the scatter of the next).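

In this assay, hydrogen in place of methyl on the saturated chain carbon bound to an amide-type nitrogen and a saturated chain carbon gives a 2.1-fold higher number from compound 2 to compound 3 (0.32 log units; beyond the scatter) with the 3-bromo-4-fluorophenyl group held constant, so this chain position affects the read-out. On the unmethylated chain, 3-bromo-4-fluorophenyl in place of 3-chlorophenyl on an amine nitrogen gives a 1.1-fold lower number from compound 1 to compound 3 (0.05 log units; within the scatter) and does not separate the two compounds. Nothing measured here accounts for the methyl step.

On these data alone, whether that step carries over to the 3-chlorophenyl compound remains open. So does the outcome with an ethyl or hydroxymethyl group on that carbon.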